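Replacing the carboxypropyl chain with an aminopropylamino group

A few compounds are considered here, and "the series" means these few. Any claim that something is new, unique, unknown or untested is made for them only; others in the source may bear on it.

Compound 1 `Cc1cn(C2CC(N=[N+]=[N-])C(COC(=O)OCCO)O2)c(=O)[nH]c1=O`, compound 2 `Cc1cn(C2CC(N=[N+]=[N-])C(COC(=O)OCCCC(=O)O)O2)c(=O)[nH]c1=O` and compound 3 `Cc1cn(C2CC(N=[N+]=[N-])C(COC(=O)CCCC(=O)O)O2)c(=O)[nH]c1=O` share one core and differ only in the chain carried on the carbonyl carbon. In a functional assay on MT4 cells (Homo sapiens) for cytotoxicity (on this read-out higher numbers stand for lower toxicity in this test and lower numbers for higher toxicity in this test), compound 1 reaches only a limit of the assay, > 50000 nM. Compound 2 likewise gives only a limit in this assay, namely > 50000 nM. Compound 3 as well stands at a limit in this assay, > 50000 nM. None of the steps among them can be sized: a step that the two limits leave unreadable from compound 1 to compound 2, a step that the two limits leave unreadable from compound 1 to compound 3 and a step that the two limits leave unreadable from compound 2 to compound 3 all remain unreadable. For the measured compounds named here, the only evidence on this read-out is the limit of > 50000 nM in this assay, at which 3 of the 3 values shown sit, and compound 3 sits exactly there, level with the other two.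

The next compound, compound 4 `Cc1cn(C2CC(N=[N+]=[N-])C(COC(=O)NCCCN)O2)c(=O)[nH]c1=O`, is set against compound 3: (3-aminopropyl)amino in place of 3-carboxypropyl on a carbonyl carbon. The measured steps from compound 1 to compound 3 and from compound 2 to compound 3 also exchanged the group on that carbonyl carbon without leaving the limit, so they offer no readable size to lean on. The step that the limit leaves unreadable from compound 3 to compound 4 is therefore expected to be none beyond the scatter, with a limit again the likeliest outcome. Compound 4 is accordingly estimated at 60000 nM, within a range from 20000 nM to 200000 nM.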

Compound 4, half-maximal cytotoxic concentration: > 50000 nM
Compound 4: no number, only a limit; the forecaster's own chance of this, stated with the estimate: 75%; the middle value does not contradict the limit.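

In this assay compound 4 also gives only a limit, > 50000 nM. The steps linking compound 4 to compound 1, compound 2 and compound 3 cannot be read, so none of them has a size. The compounds shown leave open whether any chain on the carbonyl carbon changes this read-out, since all that is available is: the limit of > 50000 nM in this assay, at which 4 of the 4 values shown sit.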